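Three Limits and a Cyclohexylmethyl Urea

The source may report more compounds than this note shows. Statements on the series, on what has been measured and on what is new or still open speak of the compounds shown alone.

Measured compounds, each tested in a functional assay on HeLa cells (Homo sapiens) for inhibition, read by MTT assay, with a stated time of 72 h (a lower number here means a stronger inhibitor, a higher number a weaker inhibitor), and each reported as a limit of the assay:

Compound 1 `Cc1cccc(NC(=O)Nc2ccc(Nc3ncnc4[nH]ncc34)cc2)c1C` gives > 10000 nM (a limit)
Compound 2 `COc1cccc(NC(=O)Nc2ccc(Oc3ncnc4[nH]ncc34)cc2)c1` gives > 10000 nM (a limit)
Compound 3 `O=C(Nc1cccc(Oc2ncnc3[nH]ncc23)c1)c1ccc(C(F)(F)F)cc1` gives > 10000 nM (a limit)

Compound 2 therefore has no number in this assay, only a limit. Among the compounds with values here, the same holds across the whole set, which offers the limit of > 10000 nM in this assay, at which 3 of the 3 values shown sit, and no measured step between two compounds.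

Compound 4 `O=C(NCC1CCCCC1)Nc1ccc(Oc2ncnc3[nH]ncc23)cc1` has not yet been measured. It departs from compound 2 by carrying cyclohexylmethyl in place of 3-methoxyphenyl on an amide-type nitrogen and keeps the rest of the structure.

With no numbers to scale from, the expectation rests on compound 2 at > 10000 nM, a limit. No step beyond the scatter is expected in this assay, in either direction. The estimated change is a step that the limit leaves unreadable from compound 2 to compound 4 and would leave the compound close to that limit. For compound 4 the estimated value is 12000 nM, with an expected range from 4000 nM to 30000 nM.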

Compound 4, half-maximal inhibitory concentration: > 10000 nM
Compound 4 was reported as a limit; the forecaster's own chance of this, stated with the estimate: 70%; the middle value is on the limit's open side.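

In this assay compound 4 gives > 10000 nM, a limit. Within the data shown here, compound 2 gives > 10000 nM, also a limit, so no step between compound 2 and compound 4 can be read. The compounds shown leave open what number any of them would reach in this assay, and whether cyclohexylmethyl or 3-methoxyphenyl serves better there.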